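The source may report more compounds than this note shows. Statements on the series, on what has been measured and on what is new or still open speak of the compounds shown alone.

Compound 2 `CCCCCCCc1c(C)nc2ccccc2c1O` and compound 1 `CCCCCCCc1c(C)nc2cc(OC)ccc2c1O` share one core and differ by methoxy in place of hydrogen on an aromatic carbon. In a physicochemical assay for lipophilicity, at pH 7.4 (a higher number here means a more lipophilic compound, a lower number a more polar compound), compound 2 gives 3.39, while compound 1 gives 3.69; the step is a number 0.30 log units higher from compound 2 to compound 1 (within the scatter). Compound 3 `Cc1[nH]c2ccccc2c(=O)c1Cc1ccccc1` rests on another core; how that core differs from the core of compound 2 is not broken down here. In this assay compound 3 gives 1.93, the lowest of the three numbers. Compound 4 `COc1cccc2[nH]c(C)c(Cc3ccccc3)c(=O)c12` has not yet been measured. It differs from compound 3 by methoxy in place of hydrogen on an aromatic carbon, the same kind of change as that from compound 2 to compound 1, though here the methoxy sits ortho to a fused ring and meta to a fused ring, whereas in compound 1 it sits meta to a fused ring and para to a fused ring. The expected step is a number 0.27 log units higher from compound 3 to compound 4 (within the scatter). Within the data shown here, that expectation rests on the one measured step of this kind, a number 0.30 log units higher from compound 2 to compound 1 (within the scatter). Compound 4 is estimated at 2.2, between 1.8 and 2.7.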

Compound 4, distribution coefficient: 2.11
Compound 4: middle estimate off by 0.09 log units, on the high side; measured number inside the range.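

In this assay, methoxy in place of hydrogen on an aromatic carbon gives a number 0.18 log units higher from compound 3 to compound 4 (within the scatter) and on the other core gives a number 0.30 log units higher from compound 2 to compound 1 (within the scatter) and so, with both steps within the scatter, the change carried across the two cores without a step beyond the scatter. Among these compounds, this does not show that methoxy moves the number on either core, and with only two pairs, and the methoxy of compound 4 ortho to a fused ring and meta to a fused ring, it establishes no general rule for the series. Nothing available explains either step.

From the compounds shown here alone, it remains open whether an amine or a carboxylic acid on the same aromatic carbon would give a step beyond the scatter. Going by these compounds, how methoxy would behave on the aromatic carbons of these cores that are not represented here also remains open.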